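The source may hold more compounds than are shown below. What is called first, only, known or untested is meant among the compounds shown, and "the series" means these compounds.

Compound 1 `Fc1ccc(-c2nn(-c3ccccc3)cc2-c2nc3cc(Cl)ccc3[nH]2)cc1`: > 50000 nM (a limit)
Compound 2 `Fc1ccc(-c2nn(-c3ccccc3)cc2-c2nc3cc(Br)ccc3[nH]2)cc1`: 21800 nM

Going by the values given here, in an ADME assay on HaCaT cells (Homo sapiens) for cytotoxicity, read by MTT assay, with a stated time of 48 h (a lower number here means a stronger inhibitor, a higher number a weaker inhibitor), compound 2 gives 21800 nM, the only actual number so far. Compound 1 stands at > 50000 nM, which is a limit of the assay and not a number. Compound 3 `Cc1ccc2[nH]c(-c3cn(-c4ccccc4)nc3-c3ccc(F)cc3)nc2c1` has methyl in place of bromo on an aromatic carbon. Among the compounds with values here, one measured step bears on this change, and only indirectly: bromo in place of chloro gave an at least 2.2-fold lower number from compound 1 to compound 2 (0.36 log units; beyond the scatter), an at least modest change whose exact size remains unknown. That step shows that the group at this place can shift the reading in this assay, although it does not involve methyl. Losing bromo is therefore expected to move the number upward, and the estimated step is a 2.1-fold higher number from compound 2 to compound 3 (0.31 log units; beyond the scatter). For compound 3 the expected value is 45000 nM, with an estimated range from 20000 nM to 100000 nM.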

Compound 3, half-maximal inhibitory concentration: > 50000 nM
Compound 3: a limit, no number; the forecaster's own chance of this, stated with the estimate: 45%; middle value at least 1.1-fold (0.04 log units) from the limit.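

In this assay, methyl in place of bromo on the aromatic carbon gave an at least 2.2-fold higher number from compound 2 to compound 3 (0.36 log units; beyond the scatter), so bromo now stands apart at this position from methyl as well as from chloro. Compound 3 gives > 50000 nM, which is a limit and not a number. The step from compound 1 to compound 3 cannot be read, and the change from bromo to methyl has only a minimum size, because the readings stop at the same limit: the limit of > 50000 nM in this assay, at which 2 of the 3 values shown sit.

The compounds shown leave open how far chloro and methyl lie from each other, and whether bromo is the only group at this position that gives a number in this assay. On these data alone, how an amine, a carboxylic acid or a longer chain would read here also stays open.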